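The source may report more compounds than this note shows. Statements on the series, on what has been measured and on what is new or still open speak of the compounds shown alone.

Compound 2 `CC(C)(C)c1ccc(OCCCON2C(N)=NC(N)=NC23CCSCC3)cc1` and compound 3 `COc1ccc(OCCCON2C(N)=NC(N)=NC23CCSCC3)cc1` share one core and differ only on the aromatic ring. In an assay on isolated protein for inhibition of Dihydrofolate reductase (Homo sapiens), read by spectrophotometry, using NADPH, with stated times of 5 s and 6 min, tested at 50 uM (a lower number here means a weaker effect, a higher number a stronger effect of the compound at the concentration tested), compound 2 gives 86.6%, and compound 3 gives 86.6%; the step of no change at the digits printed from compound 2 to compound 3 (within the scatter) lies within the scatter, so compound 3 stands level with compound 2. Compound 1 `NC1=NC2(CCOCC2)N(OCCCOc2ccc(Cl)cc2Cl)C(N)=N1`, built on a different core, has in this assay only "not determined" (no result reported). Compound 4 `NC1=NC2(CCSCC2)N(OCCCOc2cccc(Br)c2)C(N)=N1` differs from compound 3 by 3-bromophenyl in place of 4-methoxyphenyl on an oxygen on a saturated carbon. For the measured compounds named here, the single measured step, from compound 2 to compound 3, also changed the aromatic ring and was flat, so no move in this assay beyond the scatter is expected for compound 4. Compound 4 is therefore expected at 85%, between 70% and 95%. The expected step of a number 1.6 percentage points lower from compound 3 to compound 4 (within the scatter) stays within the scatter.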

Compound 4, a percentage reported as inhibition, at one concentration (the size of the read-out at that concentration, not a potency): 86.5%
Estimate against measurement, compound 4: 1.5 percentage points below; low and high end bracket the measured number.
By their numbers in this assay, from the lowest: compounds 4, 2 and 3 (each within the scatter of the next).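

Exchanging the 4-methoxyphenyl for 3-bromophenyl on an oxygen on a saturated carbon gives a number 0.1 percentage points lower from compound 3 to compound 4 (within the scatter) in this assay. The position therefore holds its level not only across the earlier change of group from compound 2 to compound 3, but also with a bromine-bearing ring that has no hydrogen-bond acceptor. Nothing available explains this flat result. Still open, on these data alone, is whether an amine, a carboxylic acid or a longer chain at this place would hold the level. A read-out at one concentration also leaves open whether compound 2, compound 3 and compound 4 would show an effect of the same size at other concentrations.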